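This account rests on a few compounds, and the source may have more. Where it says the series, first, only, none or still open, it means among the compounds named here.

Measured so far in an assay on CHO cells for agonist activity at Neuronal acetylcholine receptor; alpha3/alpha6/beta2/beta3 (Homo sapiens), read by FLIPR and calcium flux; on this read-out lower numbers stand for smaller maximal responses and higher numbers for larger maximal responses:
compound 1 `CCC(=O)N1CC2CC(C1)N2` gives 120%
compound 2 `CC(C)C(=O)N1CC2CC(C1)N2` gives 45%

Among these two numbers compound 2 stands lowest; its nearest neighbour is compound 1, and the step of a number 75 percentage points lower from compound 1 to compound 2 (beyond the scatter) lies beyond the scatter. Compound 3 `O=C([C@H]1C[C@H]1F)N1CC2CC(C1)N2` has not yet been measured. It differs from compound 2 by 2-fluorocyclopropyl in place of isopropyl on a carbonyl carbon. Among the compounds with values here, only one measured step bears on this change: the step from compound 1 to compound 2 also altered the group on the carbonyl carbon, and it was large, a number 75 percentage points lower from compound 1 to compound 2 (beyond the scatter). The change to compound 3 is of a different kind, so neither its direction nor its size can be read from that step alone; it shows only that this position moves the maximal response strongly. For compound 3 a step of a number 25 percentage points higher from compound 2 to compound 3 (beyond the scatter) is expected, with wide uncertainty. Compound 3 is therefore estimated at 70%, between 25% and 120%.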

Compound 3, largest response reached (Emax), in percent of the reference or control that the assay uses: 130%
Compound 3: middle estimate off by 60 percentage points, on the low side; measured number outside the range, above it.
By their numbers in this assay, from the lowest: compound 2; then compounds 1 and 3 (each within the scatter of the next).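

In this assay, the group on the carbonyl carbon can raise the maximal response as well as lower it: 2-fluorocyclopropyl in place of isopropyl gives a number 85 percentage points higher from compound 2 to compound 3 (beyond the scatter), and 2-fluorocyclopropyl in place of ethyl gives a number 10 percentage points higher from compound 1 to compound 3 (within the scatter). The low number of compound 2 therefore does not hold for every group here with more heavy atoms than ethyl, and a ring carrying fluorine restores the level of compound 1. Nothing measured here explains why these groups differ so sharply.

From the compounds shown here alone, what remains open is whether the three-membered ring or the fluorine accounts for the step, which a plain cyclopropyl group would help to separate. Also open, going by these compounds, are the role of the two defined stereocentres, which the mirror-image 2-fluorocyclopropyl group could test, and the response with a tert-butyl group on the carbonyl carbon.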